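A few compounds are considered here, and "the series" means these few. Any claim that something is new, unique, unknown or untested is made for them only; others in the source may bear on it.

Of the compounds shown here, two have so far been measured in a functional assay on the whole organism for inhibition, with Mus musculus as the target, at a dose of 150 mg/kg by the intraperitoneal route; a lower number here means less inhibition, a higher number more inhibition at the dose given (going by the name of the read-out). Compound 1 `CC(C)n1nc(-c2cccc(C(F)(F)F)c2)c2c1/C(=C/c1cccc(C(F)(F)F)c1)CS(=O)(=O)C2` gives 21% there. Compound 2 `CCCN1N=C2/C(=C/c3ccccc3)CSCC2C1c1ccccc1` gives 21%, level with compound 1 at the digits shown, a gap that lies within the usual scatter of repeated measurements of this kind. Among the measured compounds shown here, no pair of measured compounds differing in only one place is available, so nothing here shows how a single structural change moves this read-out. Compound 3 `OCCN1N=C2/C(=C/c3ccccc3)CSCC2C1c1ccccc1` has not yet been measured. It differs from compound 2 in one place: hydroxy in place of methyl on a saturated chain carbon, two bonds along the chain from an amine nitrogen in a ring. For the measured compounds named here, since no measured pair shows what such an exchange does, the step is expected to stay within the scatter, with no clear direction; a number 1 percentage points lower from compound 2 to compound 3 (within the scatter) is what the estimate implies. In this assay compound 3 is expected to give about 20%, in a range from 5% to 40%.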

Compound 3, a percentage reported as inhibition, in the whole organism at one dose (the size of the read-out at that dose, not a potency): 21%
Compound 3: the middle estimate sits 1 percentage points below what was measured; the range from low to high includes it.
By their numbers in this assay, from the lowest: compounds 1, 2 and 3 (each within the scatter of the next).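

Among the compounds shown here, putting hydroxy in place of methyl on a saturated chain carbon, two bonds along the chain from an amine nitrogen in a ring, gives the first reading of a single change in this assay, with no change at the digits printed from compound 2 to compound 3 (within the scatter). At this one dose, the read-out therefore does not separate propyl from 2-hydroxyethyl at this position, even though the entering hydroxy carries 1 hydrogen-bond donor and 1 hydrogen-bond acceptor, and the methyl it replaces carries neither. No independent measurement is available to explain this outcome.

As far as these compounds go, it remains open whether an amine or a carboxylic acid at the end of this chain, or a longer chain such as 3-hydroxypropyl, would move the read-out. This single step also cannot show whether the same exchange would give a similar result at another dose or on a different core.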